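Adding methoxy to the phenylsulfonyl group

The compounds below may be only part of what the source reports. "The series", "measured", "known", "first", "only" and "open" are said of these compounds alone.

In a functional assay on HeLa cells (Homo sapiens) for antiproliferative activity, read by MTT assay, with a stated time of 24 h (on this read-out lower numbers stand for stronger inhibition and higher numbers for weaker inhibition), compound 1 `FC(F)(F)c1ccc(-c2nn(-c3ccccc3)cc2-c2nc3ccccc3[nH]2)cc1` gives 4670 nM. Adding a sulfonyl group brings compound 3 `O=S(=O)(c1ccccc1)n1c(-c2cn(-c3ccccc3)nc2-c2ccc(C(F)(F)F)cc2)nc2ccccc21` to 560 nM, and compound 2 `COc1ccc(S(=O)(=O)n2c(-c3cn(-c4ccccc4)nc3-c3ccc(F)cc3)nc3ccccc32)cc1` gives 390 nM. Compound 3 thus sits within the scatter of compound 2 and well under compound 1.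

Compound 4 `COc1ccc(S(=O)(=O)n2c(-c3cn(-c4ccccc4)nc3-c3ccc(C(F)(F)F)cc3)nc3ccccc32)cc1` differs from compound 3 by methoxy in place of hydrogen on an aromatic carbon, para to a large group, so that phenylsulfonyl becomes (4-methoxyphenyl)sulfonyl: methoxy in place of hydrogen on an aromatic carbon.

Among the compounds with values here, the only measured step nearby is an 8.3-fold lower number from compound 1 to compound 3 (0.92 log units; beyond the scatter), a modest change beyond the scatter. It introduces the phenylsulfonyl group and does not measure any change made on it, so it bears only indirectly on this question. The two sulfonyl compounds, compound 2 at 390 nM and compound 3 at 560 nM, lie close together, so no step beyond the scatter is expected in this assay.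

The estimate amounts to a 1.2-fold lower number from compound 3 to compound 4 (0.09 log units; within the scatter), which is expected to stay within the scatter. Compound 4 is expected at 450 nM, with an estimated range of 200 nM to 1000 nM.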

Compound 4, half-maximal inhibitory concentration: 250 nM
Beside the measured number, compound 4's estimate is 1.8-fold (0.26 log units) above it; the measured number falls inside the stated range.
By their numbers in this assay, from the lowest: compounds 4, 2 and 3 (each within the scatter of the next, the first and the last beyond it); then compound 1.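

In this assay, within the data shown here, methoxy in place of hydrogen on the phenylsulfonyl ring gives the first reading of a change on that ring itself: a 2.2-fold lower number from compound 3 to compound 4 (0.35 log units; beyond the scatter) is a modest step, just beyond the scatter. With that methoxy group in place, trifluoromethyl in place of fluoro gives a 1.6-fold lower number from compound 2 to compound 4 (0.19 log units; within the scatter) and stays within the scatter, while the whole (4-methoxyphenyl)sulfonyl group on the aromatic nitrogen gives a 19-fold lower number from compound 1 to compound 4 (1.27 log units; beyond the scatter) and is a large step, against the modest 8.3-fold lower number from compound 1 to compound 3 (0.92 log units; beyond the scatter) for phenylsulfonyl alone. Nothing available accounts for the size of the methoxy step.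

From the compounds shown here alone, it remains open whether an amine or a hydroxyl group in the same place, para to a large group, would read like methoxy. Going by these compounds, it is also open whether the methoxy step holds when fluoro replaces trifluoromethyl.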